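Amide-region variation on the shared core: compound 3

A few compounds are considered here, and "the series" means these few. Any claim that something is new, unique, unknown or untested is made for them only; others in the source may bear on it.

Compound 2 `Cc1cc(NC(=O)C2CCOC2)nn1Cc1cc(Cl)ccc1OCc1ccccc1` gives 39.8 nM in an assay on CHO-K1 cells for displacement of a labelled ligand from prostaglandin E2 receptor EP1 subtype (Homo sapiens) (on this read-out lower numbers stand for stronger inhibition and higher numbers for weaker inhibition), and compound 1 `Cc1cc(C(=O)NCc2ccccn2)nn1Cc1cc(Cl)ccc1OCc1ccccc1` gives 25.1 nM, so the two numbers to hand sit within the scatter of each other and no order between them is claimed; the step of a 1.6-fold higher number from compound 1 to compound 2 (0.20 log units; within the scatter) is the whole record so far. Compound 3 `Cc1cc(NC(=O)c2c(F)cccc2F)nn1Cc1cc(Cl)ccc1OCc1ccccc1` differs from compound 2 by 2,6-difluorophenyl in place of oxolan-3-yl on a carbonyl carbon. For the measured compounds named here, the only measured step touching this part of the shared core is a 1.6-fold higher number from compound 1 to compound 2 (0.20 log units; within the scatter), which changed both the amide arrangement and the group carried on it and moved the number by little. Going by the values given here, no measured step has an aromatic ring entering at this carbonyl carbon, so the direction rests on the general tolerance seen in a 1.6-fold higher number from compound 1 to compound 2 (0.20 log units; within the scatter). The expected step in this assay is a 1.4-fold lower number from compound 2 to compound 3 (0.15 log units; within the scatter), with no direction beyond the scatter. Compound 3 is estimated at 28 nM, with a range from 8 nM to 100 nM.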

Compound 3, half-maximal inhibitory concentration: 12.6 nM
The estimate for compound 3 lay 2.2-fold (0.35 log units) above the measured number, within the range that was stated.
By their numbers in this assay, from the lowest: compounds 3, 1 and 2 (each within the scatter of the next, the first and the last beyond it).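

In this assay, for the compounds shown here, the carbonyl carbon on the amide-type nitrogen accepts an aromatic ring, and 2,6-difluorophenyl in place of oxolan-3-yl gives a 3.2-fold lower number from compound 2 to compound 3 (0.50 log units; beyond the scatter) as the first step beyond the scatter. Set against the ((pyridin-2-yl)methyl)carbamoyl group on the aromatic carbon, the ((2,6-difluorophenyl)carbonyl)amino group gives a 2.0-fold lower number from compound 1 to compound 3 (0.30 log units; within the scatter) so no order is claimed for that pair. Nothing at hand offers an explanation for the step at the carbonyl carbon.

Still open, on these data alone, is how plain phenyl, without the two fluorines, would read at this carbonyl carbon, and how a ring carrying an amine or a carboxylic acid would read there. The compounds shown also leave the rest of the shared core unvaried, so whether this step carries over to other cores remains unknown.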